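Swapping the tert-butylphenyl amide for a difluorophenyl

The source may report more compounds than this note shows. Statements on the series, on what has been measured and on what is new or still open speak of the compounds shown alone.

Compound 1 `COc1cc2ncnc(Nc3ccc(NC(=O)c4ccc(C(C)(C)C)cc4)cc3)c2cc1OC`: in a functional assay on HepG2 cells (Homo sapiens) for inhibition, read by MTT assay (a higher number here means a weaker inhibitor, a lower number a stronger inhibitor), compound 1 gives > 100000 nM, which is a limit of the assay rather than a number.
Compound 2 `COc1cc2ncnc(Nc3ccc(NC(=O)c4cccc(Cl)c4)cc3)c2cc1OC`: in this assay compound 2 gives 12000 nM.

Compound 1 therefore has no exact value here; all that is known is the limit, (the limit of > 100000 nM in this assay, at which 1 of the 2 values shown sits). Compound 3 `COc1cc2ncnc(Nc3ccc(NC(=O)c4c(F)cccc4F)cc3)c2cc1OC` differs from compound 1 in one place: 2,6-difluorophenyl in place of 4-(tert-butyl)phenyl on a carbonyl carbon. For the measured compounds named here, only one measured step bears on such a change, an at least 8.3-fold lower number from compound 1 to compound 2 (0.92 log units; beyond the scatter), where another substituted phenyl also replaced the 4-(tert-butyl)phenyl on the carbonyl carbon. That step was at least modest and lowered the number, so a change of similar size and direction is expected for the new amide. The estimated step is an at least 5.0-fold lower number from compound 1 to compound 3 (0.69 log units; beyond the scatter). Compound 3 is accordingly estimated at 20000 nM, with a likely range from 5000 nM to 100000 nM.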

Compound 3, half-maximal inhibitory concentration: 17000 nM
For compound 3 the middle estimate is 1.2-fold (0.07 log units) above the measured one, and the stated range covers the measured number.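

In this assay a second substituted phenyl on the carbonyl carbon also gives a lower number than the 4-(tert-butyl)phenyl amide (an at least 5.8-fold lower number from compound 1 to compound 3 (0.76 log units; beyond the scatter)). The 2,6-difluorophenyl and 3-chlorophenyl amides cannot be told apart (a 1.4-fold higher number from compound 2 to compound 3 (0.15 log units; within the scatter)), so these two differently substituted rings sit at about the same level at this position. The true size of the steps from compound 1 stays unknown because its value is only a limit: the limit of > 100000 nM in this assay, at which 1 of the 3 values shown sits.

The compounds shown leave open whether a plain phenyl with no substituent would sit at the same level as these two amides. They also leave open how a phenyl carrying an amine or a carboxylic acid would behave here, or whether a short alkyl chain could replace the ring altogether.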